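The source may report more compounds than this note shows. Statements on the series, on what has been measured and on what is new or still open speak of the compounds shown alone.

Compound 1 `O=C(Oc1ccc(Cl)cc1C(=O)Nc1ccc(Cl)c(Cl)c1)c1cnc(Cl)cn1` and compound 2 `O=C(Oc1ccc(Br)cc1C(=O)Nc1ccc(Cl)c(Cl)c1)c1cnc(Cl)cn1` share one core, while compound 3 `O=C(NCCCCl)Oc1ccc(Cl)cc1C(=O)Nc1ccc(C(F)(F)F)cc1` and compound 4 `O=C(NCCCCl)Oc1ccc(Br)cc1C(=O)Nc1ccc(C(F)(F)F)cc1` share another; the difference between the two cores is not broken down here. In an ADME assay on MONO-MAC-6 cells (Homo sapiens) for cytotoxicity, read by MTT assay, with a stated time of 16 h (a higher number here means a weaker inhibitor, a lower number a stronger inhibitor), compound 1 gives 10100 nM, and compound 2 gives 5700 nM, so that a 1.8-fold lower number from compound 1 to compound 2 (0.25 log units; within the scatter) accompanies the change (bromo in place of chloro on an aromatic carbon). In this assay compound 3 gives 8800 nM. The change from compound 3 to compound 4 is the same kind of change, (bromo in place of chloro on an aromatic carbon), although here the carbon bearing the halogen is para to a ((3-chloropropyl)carbamoyl)oxy group (8 heavy atoms) rather than para to a large group. For compound 4 the expected step is a 1.6-fold lower number from compound 3 to compound 4 (0.20 log units; within the scatter), resting on compound 3 at 8800 nM together with a 1.8-fold lower number from compound 1 to compound 2 (0.25 log units; within the scatter). Compound 4 is thus estimated at 5500 nM, with a range from 3000 nM to 11000 nM.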

Compound 4, half-maximal inhibitory concentration: 5700 nM
The estimate for compound 4 lay 1.0-fold (0.02 log units) below the measured number; low and high end bracket the measured number.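

In this assay, bromo in place of chloro on the aromatic carbon gives a 1.5-fold lower number from compound 3 to compound 4 (0.19 log units; within the scatter), so on this second core too the step stays within the scatter. The two cores agree on this change: the same change on two cores in this assay, a 1.8-fold lower number (0.25 log units; within the scatter) from compound 1 to compound 2 and a 1.5-fold lower number (0.19 log units; within the scatter) from compound 3 to compound 4, 1.1-fold (0.06 log units) apart, within the scatter of two such steps. This shows that the small step carries over between these two cores, but it does not show that the change has any real effect of its own, and it says nothing about other cores in the series.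

The compounds shown leave open what fluoro, methyl or an amine would give on this same aromatic carbon. They also leave open whether a longer chain in the ((3-chloropropyl)carbamoyl)oxy group would alter the step.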